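This account rests on a few compounds, and the source may have more. Where it says the series, first, only, none or still open, it means among the compounds named here.

Of the compounds shown here, two of a shared core have been measured in an ADME assay on L02 cells (Homo sapiens) for cytotoxicity, read by MTT assay, with a stated time of 24 h; on this read-out lower numbers stand for stronger inhibition and higher numbers for weaker inhibition. Compound 1 `Cc1ccc(S(=O)(=O)N2C/C(=C\c3ccccc3F)C(=O)/C(=C/c3ccccc3F)C2)cc1` gives 16700 nM in this assay. Compound 2 `O=C1/C(=C/c2ccccc2F)CN(S(=O)(=O)c2ccc(Br)cc2)C/C1=C\c1ccccc1F` gives 16200 nM in this assay. The one step between them, a 1.0-fold lower number from compound 1 to compound 2 (0.01 log units; within the scatter), changes only the group on the sulfonyl-bearing aryl ring, and the two numbers lie within the scatter of each other, so nothing separates compound 2 from compound 1 on the numbers shown.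

Compound 3 `CC(=O)Nc1ccc(S(=O)(=O)N2C/C(=C\c3ccccc3F)C(=O)/C(=C/c3ccccc3F)C2)cc1` is the next member of the series. Its difference from compound 2 is acetamido in place of bromo on an aromatic carbon. Going by the values given here, the only measured step that bears on this change is a 1.0-fold lower number from compound 1 to compound 2 (0.01 log units; within the scatter), which swapped one group for another at the same place on the same ring and produced no step beyond the scatter. With a single comparison of that kind, and the new group differing from both earlier ones, the expectation in this assay is a step of a 1.0-fold higher number from compound 2 to compound 3 (0.01 log units; within the scatter), that is, none beyond the scatter. Compound 3 is therefore estimated at 16500 nM, with a range from 8000 nM to 34000 nM.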

Compound 3, half-maximal inhibitory concentration: 11500 nM
Compound 3: the middle estimate sits 1.4-fold (0.16 log units) above what was measured; the measured number falls inside the stated range.
By their numbers in this assay, from the lowest: compounds 3, 2 and 1 (each within the scatter of the next).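

In this assay, acetamido brings 4 heavy atoms, a hydrogen-bond donor and a hydrogen-bond acceptor to the aromatic carbon para to a large group, where bromo carries 1 heavy atom and no donor or acceptor, and the result is a 1.4-fold lower number from compound 2 to compound 3 (0.15 log units; within the scatter). Set against methyl at the same place, the same group gives a 1.5-fold lower number from compound 1 to compound 3 (0.16 log units; within the scatter), so methyl, bromo and acetamido all stand within the scatter of one another, and the insensitivity seen so far between two small groups now extends to a larger group with an amide hydrogen. Nothing given here accounts for this lack of separation.

As far as these compounds go, whether a free amine or a carboxylic acid on this aromatic carbon, or a longer chain in place of the acetyl part of acetamido, would bring a step beyond the scatter remains open. All three compounds also share the rest of the core, so the effect of a change anywhere else in it cannot be read from them.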